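Swapping one five-membered ring on an amide nitrogen

The source may report more compounds than this note shows. Statements on the series, on what has been measured and on what is new or still open speak of the compounds shown alone.

In a functional assay on cells (Mast cell, Rattus norvegicus) for inhibition, with a stated time of 15 min (on this read-out lower numbers stand for an effect already at smaller amounts and higher numbers for an effect only at larger amounts of compound), three compounds have been tested so far, and the record is thin. Compound 1 (`O=C(Cl)c1ccc2occc(=O)c2c1`) is recorded as "nd(insoluble)" (no result reported) and so offers no result. Going by the values given here, compound 2 (`O=C(O)C(c1coc2ccccc2c1=O)c1coc2ccccc2c1=O`) gives 8 ug/mL and is the only one with a true number. For compound 3 (`Cn1nnnc1NC(=O)c1cc(=O)c2ccccc2o1`) the entry > 18 ug/mL is a limit of the assay and not a number.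

Compound 4 (`O=C(Nc1nc[nH]n1)c1cc(=O)c2ccccc2o1`) differs from compound 3 in one place: 1H-1,2,4-triazol-3-yl in place of 1-methyl-1H-tetrazol-5-yl on an amide-type nitrogen. A change in a single place is useful, since anything that follows can be tied to that one group. Yet no two measured compounds differ in just one place, so no measured step shows what such a swap does here.

Among the compounds with values here, compound 3 with its limit of > 18 ug/mL is the only guide, so no step beyond the usual scatter is expected, in either direction. The step expected is a number no higher from compound 3 to compound 4 (the limit leaves the size open) and it stays inside that scatter. For compound 4 the estimated value is 18 ug/mL with an expected range of 6 ug/mL to 50 ug/mL and the assay may again report only a limit.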

Compound 4, concentration for half-maximal effect: 5 ug/mL
The estimate for compound 4 lay 3.6-fold (0.56 log units) above the measured number; the measured number lies below the stated range.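

Going by these compounds alone, this is the first step between two measured compounds that differ in one place: with 1H-1,2,4-triazol-3-yl in place of 1-methyl-1H-tetrazol-5-yl on an amide-type nitrogen, this assay shows an at least 3.6-fold lower number from compound 3 to compound 4 (0.55 log units; beyond the scatter). The shared core therefore does not settle the read-out on its own, and the five-membered ring on this nitrogen can shift the result beyond the usual scatter. The true size of the step remains unknown, and only its minimum can be given, because its starting point is a limit of the assay and not a number: the limit of > 18 ug/mL in this assay, at which 1 of the 4 values shown sits.

The swap changes several things at once, since the entering ring has one hetero atom fewer, carries a hydrogen-bond donor where the leaving ring has none, and lacks the methyl group, and the compounds shown cannot separate these differences. On these data alone, it also remains open how the read-out would respond to a 1H-tetrazol-5-yl, which would remove only the methyl group, or to a 1-methyl-1H-1,2,4-triazol-3-yl, which would keep the methyl group on the triazole ring.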